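A few compounds are considered here, and "the series" means these few. Any claim that something is new, unique, unknown or untested is made for them only; others in the source may bear on it.

Going by the values given here, in a functional assay on SW480 cells (Homo sapiens) for antiproliferative activity, read by MTT assay, with a stated time of 48 h (a higher number here means a weaker inhibitor, a lower number a stronger inhibitor), compound 1 (`CCCCCCC(CCO)n1cnc2c(Cl)ncnc21`) reads 16700 nM and compound 2 (`CCCCCCCCCC(CCO)n1cnc2c(Cl)ncnc21`) reads 1150 nM as the lower of the two numbers so far. The large step between them (a 15-fold lower number from compound 1 to compound 2 (1.16 log units; beyond the scatter)) leaves the 2-hydroxyethyl group in place. Compound 3 (`C=C(CO)C(CCCCCCCCC)n1cnc2c(Cl)ncnc21`) replaces that group with 1-(hydroxymethyl)ethenyl (1-(hydroxymethyl)ethenyl in place of 2-hydroxyethyl on a saturated chain carbon bound to an aromatic nitrogen and a saturated chain carbon). Among the compounds with values here, no measured step changes this group, so the one step available gives no size to carry over, and this assay is expected to show no step beyond the scatter. The estimated step is small (a 1.3-fold higher number from compound 2 to compound 3 (0.12 log units; within the scatter)) but uncertain. For compound 3 the expected value is 1500 nM (estimated range 400 nM to 6000 nM).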

Compound 3, half-maximal inhibitory concentration: 27600 nM
Compound 3: the middle estimate sits 18-fold (1.26 log units) below what was measured, and the stated range ends below it.
By their numbers in this assay, from the lowest: compound 2; then compounds 1 and 3 (each within the scatter of the next).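

At this position, on a saturated chain carbon bound to an aromatic nitrogen and a saturated chain carbon, this assay shows 1-(hydroxymethyl)ethenyl in place of 2-hydroxyethyl giving a 24-fold higher number from compound 2 to compound 3 (1.38 log units; beyond the scatter) with the nonyl chain unchanged. The number therefore responds to this group as well as to the chain change seen earlier. No measurement here offers an explanation for the step.

The compounds shown do not separate the double bond from the added carbon as the source of the step. Neither do they show how a 3-hydroxypropyl group or an amine in place of the hydroxyl would read here.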